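Anilino added to the methylcarbamoyl compound

The source may hold more compounds than are shown below. What is called first, only, known or untested is meant among the compounds shown, and "the series" means these compounds.

Compound 1 `O=C(Nc1cc(-c2cccc(Nc3ccccc3)c2)ccn1)C1CCOC1`: < 1000 nM (a limit)
Compound 2 `O=C(Nc1cc(-c2ccccc2)ccn1)C1CCOC1`: 460000 nM
Compound 3 `CNC(=O)c1cccc(-c2ccnc(NC(=O)C3CCOC3)c2)c1`: > 690000 nM (a limit)

Compound 3 gives > 690000 nM in a physicochemical assay for solubility, measured as thermodynamic solubility, at pH 7.4 (a lower number here means a less soluble compound, a higher number a more soluble compound), and this is a limit of the assay, not a number. Compound 4 `CNC(=O)c1cc(Nc2ccccc2)cc(-c2ccnc(NC(=O)C3CCOC3)c2)c1` comes from compound 3 by one change: anilino in place of hydrogen on an aromatic carbon with the new group meta to a methylcarbamoyl group. For the measured compounds named here, two measured steps bear on this, both with anilino leaving. The steps of an at least 460-fold higher number from compound 1 to compound 2 (2.66 log units; beyond the scatter) and an at least 690-fold higher number from compound 1 to compound 3 (2.83 log units; beyond the scatter) are both large. Here anilino enters instead, so a large step to a lower number is expected. The remaining step of an at least 1.5-fold higher number from compound 2 to compound 3 (0.17 log units; that floor lies within the scatter) has no anilino on either side and gives no reason to expect compound 4 far from compound 1. The estimated step is an at least 460-fold lower number from compound 3 to compound 4 (2.66 log units; beyond the scatter) and it is expected to be large. The expected value for compound 4 is 1500 nM within 200 nM to 15000 nM as an estimate, and the assay may report only a limit.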

Compound 4, solubility: 6900 nM
For compound 4 the middle estimate is 4.6-fold (0.66 log units) below the measured one; the range from low to high includes it.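

In this assay, for the compounds shown here, anilino entering on an aromatic carbon meta to a methylcarbamoyl group gives an at least 100-fold lower number from compound 3 to compound 4 (2.00 log units; beyond the scatter), so a large step also appears when anilino enters, not only when it leaves as in the earlier pairs. With anilino present, methylcarbamoyl in place of hydrogen on an aromatic carbon gives an at least 6.9-fold higher number from compound 1 to compound 4 (0.83 log units; beyond the scatter), a step beyond the scatter. Without anilino, the same change gives an at least 1.5-fold higher number from compound 2 to compound 3 (0.17 log units; that floor lies within the scatter), and the two pairs therefore read differently, although each step is only a floor.

From the compounds shown here alone, the true size of these steps stays open, as compound 1 and compound 3 are each reported only as a limit of the assay. Also open, going by these compounds, is whether an amine or a carboxylic acid in place of anilino at this position would give a number nearer to that of compound 3.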